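The compounds below may be only part of what the source reports. "The series", "measured", "known", "first", "only" and "open" are said of these compounds alone.

Measured compounds:
- compound 1, `CC1=C(C(=O)OCC(C)C)C(c2cccs2)NC(=O)N1`: 25%
- compound 2, `CC1=C(C(=O)OCc2ccccc2)C(c2ccoc2)NC(=S)N1`: 25%
- compound 3, `CC1=C(C(=O)OCC(C)C)C(c2cccs2)NC(=O)N1C`: 9%

In an assay on membranes from CHO cells for displacement of a labelled ligand from adenosine receptor A1 (Homo sapiens), read by scintillation counting, with a stated time of 60 min, tested at 1 uM (on this read-out lower numbers stand for less inhibition and higher numbers for more inhibition at the one concentration tested (going by the name of the read-out)), compound 1 gives 25%. On the numbers shown compound 1 stands level with compound 2 at the digits shown, the two together forming the highest of the three values, and compound 3 lies furthest away, a step of a number 16 percentage points lower from compound 1 to compound 3 (beyond the scatter). That one measured step consists of methyl in place of hydrogen on an amide-type nitrogen in a ring; it does not touch the ester chain and so bears only weakly on the change now considered.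

Compound 4, `CC1=C(C(=O)OCC2CCC2)C(c2cccs2)NC(=O)N1`, differs from compound 1 by cyclobutyl in place of isopropyl on a saturated chain carbon bound to an oxygen next to a carbonyl group. Going by the values given here, no measured pair alters this position, so no step of known size applies. In this assay the exchange of one small saturated alkyl group for another of similar size gives no reason to expect a step beyond the scatter, in either direction.

Compound 4 is therefore expected to give about 25%, with a range of 10% to 42%. The step this estimate implies, no change at the digits printed from compound 1 to compound 4 (within the scatter), is expected to lie within the scatter.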

Compound 4, a percentage reported as inhibition, at one concentration (the size of the read-out at that concentration, not a potency): 39%
Compound 4: middle estimate off by 14 percentage points, on the low side; measured number inside the range.
By their numbers in this assay, from the lowest: compound 3; then compounds 1 and 2 (each within the scatter of the next); then compound 4.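

In this assay this position proves responsive: cyclobutyl in place of isopropyl on a saturated chain carbon bound to an oxygen next to a carbonyl group gives a number 14 percentage points higher from compound 1 to compound 4 (beyond the scatter). Going by these compounds alone, this is the first measured step at this place, and the exchange of one small saturated alkyl group for another is enough to move the number beyond the scatter, while the only earlier step, a number 16 percentage points lower from compound 1 to compound 3 (beyond the scatter), concerned an amide-type nitrogen in a ring. No available evidence bears on the reason for the rise.

The compounds shown leave open whether the four-membered ring itself matters or whether an open chain such as n-pentyl or a larger ring such as cyclopentyl would serve equally at this position. As far as these compounds go, each number is also a reading at one concentration, so the size of any difference in potency remains open.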